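Adding a Methyl Group: Effect on Cell Tolerance

This account rests on a few compounds, and the source may have more. Where it says the series, first, only, none or still open, it means among the compounds named here.

Compound 1 `CCOC(=O)c1cc2ccc(Oc3ccnc(C(=O)NC)c3)cc2s1` was tested in an ADME assay on H1-HeLa cells (Homo sapiens) for cytotoxicity, read by MTT assay, with a stated time of 3 days; a lower number here means that less compound is tolerated, a higher number that more compound is tolerated. In this assay compound 1 gives > 100000 nM, which is a limit of the assay rather than a number. Compound 2 `CCOC(=O)c1sc2cc(Oc3ccnc(C(=O)NC)c3)ccc2c1C` differs by methyl in place of hydrogen on an aromatic carbon. In this assay compound 2 gives 50900 nM. The step is an at least 1.9-fold lower number from compound 1 to compound 2 (0.29 log units; that floor lies within the scatter). Compound 3 `CNC(=O)c1cc(Oc2ccc3cc(C(=O)OC)sc3c2)ccn1` differs from compound 1 by hydrogen in place of methyl on a saturated chain carbon bound to an oxygen next to a carbonyl group. In this assay compound 3 gives > 100000 nM, again a limit of the assay. The step is a step that the two limits leave unreadable from compound 1 to compound 3. Two of the three values sit at the limit of > 100000 nM in this assay, at which 2 of the 3 values shown sit. Compound 4 `CNC(=O)c1cc(Oc2ccc3c(C)c(C(=O)OC)sc3c2)ccn1` differs from compound 3 by methyl in place of hydrogen on an aromatic carbon, the same kind of change as between compound 1 and compound 2, though in compound 4 the methyl sits next to the ring atom that bears a methoxycarbonyl group rather than an ethoxycarbonyl group. Compound 4 is expected to show an at least 1.6-fold lower number from compound 3 to compound 4 (0.22 log units; that floor lies within the scatter) in this assay, resting on an at least 1.9-fold lower number from compound 1 to compound 2 (0.29 log units; that floor lies within the scatter). The estimate for compound 4 is 60000 nM.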

Compound 4, half-maximal cytotoxic concentration: 10800 nM
Beside the measured number, compound 4's estimate is 5.6-fold (0.74 log units) above it; the measured number lies below the stated range.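

In this assay, the methyl on the aromatic carbon gives an at least 9.2-fold lower number from compound 3 to compound 4 (0.96 log units; beyond the scatter), and only on the core of compound 3 does this step clearly pass the usual scatter. The change therefore cannot be said to carry over at the same size from one core to the other: the same change on two cores in this assay, an at least 1.9-fold lower number (0.29 log units; that floor lies within the scatter) from compound 1 to compound 2 and an at least 9.2-fold lower number (0.96 log units; beyond the scatter) from compound 3 to compound 4; the limit leaves it open whether they differ With the methyl present, exchanging ethoxycarbonyl for methoxycarbonyl gives a 4.7-fold lower number from compound 2 to compound 4 (0.67 log units; beyond the scatter), whereas the same exchange without the methyl cannot be read: the limit of > 100000 nM in this assay, at which 2 of the 4 values shown sit.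

The compounds shown leave open how an ethyl group or a chlorine atom on that aromatic carbon would compare with methyl. They also leave open how a carboxylic acid in place of the ester would read in this assay.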